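The compounds below may be only part of what the source reports. "The series", "measured", "known", "first", "only" and "open" are said of these compounds alone.

Measured in an ADME assay on THP-1 cells (Homo sapiens) for cytotoxicity; a higher number here means a weaker inhibitor, a lower number a stronger inhibitor:
compound 1 `COc1ccccc1-c1nnc(-c2ccc(C(=O)N/N=C/c3c(O)cc(O)cc3O)cc2)o1`: 12400 nM
compound 2 `COc1ccccc1-c1nnc(-c2ccc(C(=O)N/N=C/c3cccc(O)c3O)cc2)o1`: 102000 nM
compound 3 `COc1ccccc1-c1nnc(-c2ccc(C(=O)N/N=C/c3cccc(O)c3)cc2)o1`: 398000 nM

Compound 1 stands lowest of the three numbers. Its nearest neighbour is reached by an 8.2-fold higher number from compound 1 to compound 2 (0.92 log units; beyond the scatter), the furthest by a 32-fold higher number from compound 1 to compound 3 (1.51 log units; beyond the scatter). Compound 4 `COc1ccccc1-c1nnc(-c2ccc(C(=O)N/N=C/c3ccc(O)cc3O)cc2)o1` differs from compound 1 as follows: hydrogen in place of hydroxy on an aromatic carbon.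

For the measured compounds named here, the one measured step of the same kind, a 3.9-fold higher number from compound 2 to compound 3 (0.59 log units; beyond the scatter), was modest and went upward. Both steps away from compound 1 also rose when hydroxy groups were removed. For compound 4 the expected outcome in this assay is therefore a modest upward step, a 3.2-fold higher number from compound 1 to compound 4 (0.51 log units; beyond the scatter), not a large one. The estimate for compound 4 is 40000 nM, expected to fall between 15000 nM and 110000 nM.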

Compound 4, half-maximal inhibitory concentration: 104000 nM
Beside the measured number, compound 4's estimate is 2.6-fold (0.41 log units) below it; low and high end bracket the measured number.
By their numbers in this assay, from the lowest: compound 1; then compounds 2 and 4 (each within the scatter of the next); then compound 3.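

In this assay, taking one hydroxy from the 2,4,6-trihydroxyphenyl group gives an 8.4-fold higher number from compound 1 to compound 4 (0.92 log units; beyond the scatter), and hydrogen in place of hydroxy now moves the number the same way on two cores: the same change on two cores in this assay, a 3.9-fold higher number (0.59 log units; beyond the scatter) from compound 2 to compound 3 and an 8.4-fold higher number (0.92 log units; beyond the scatter) from compound 1 to compound 4, 2.1-fold (0.33 log units) apart, within the scatter of two such steps The two dihydroxyphenyl patterns are not separated, with a 1.0-fold higher number from compound 2 to compound 4 (0.01 log units; within the scatter). The 2,4-dihydroxyphenyl group still differs from the 3-hydroxyphenyl group, with a 3.8-fold lower number from compound 3 to compound 4 (0.58 log units; beyond the scatter).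

On these data alone, whether a methoxy group or an amine at this place would keep the number of compound 1 remains open. So does how these changes would read in any other assay.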